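Changing the Group on the Amide-Type Nitrogen

A few compounds are considered here, and "the series" means these few. Any claim that something is new, unique, unknown or untested is made for them only; others in the source may bear on it.

In a functional assay on HT-29 cells (Homo sapiens) for cytotoxicity, read by MTT assay, with a stated time of 72 h (on this read-out higher numbers stand for weaker inhibition and lower numbers for stronger inhibition), compound 1 (`Cc1ccc(F)cc1NC(=O)CN1CCN(c2nnc(Cc3ccccc3)c3ccccc23)CC1`) gives 171000 nM, compound 2 (`O=C(CN1CCN(c2nnc(Cc3ccccc3)c3ccccc23)CC1)Nc1ccc(Br)cc1`) gives 60200 nM and compound 3 (`O=C(CN1CCN(c2nnc(Cc3ccccc3)c3ccccc23)CC1)Nc1cc(C(F)(F)F)ccc1Cl`) gives 66800 nM. Compound 3 thus lies close to one measured neighbour and apart from the other. The nearest gap is a 1.1-fold higher number from compound 2 to compound 3 (0.05 log units; within the scatter), and the widest is a 2.6-fold lower number from compound 1 to compound 3 (0.41 log units; beyond the scatter).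

Compound 4 (`O=C(CN1CCN(c2nnc(Cc3ccccc3)c3ccccc23)CC1)Nc1ccc(F)c(Cl)c1`) carries 3-chloro-4-fluorophenyl in place of 2-chloro-5-(trifluoromethyl)phenyl on an amide-type nitrogen. The same position changes in all three measured steps, the remaining one being a 2.8-fold lower number from compound 1 to compound 2 (0.45 log units; beyond the scatter). None is more than modest, so no step beyond the scatter is expected in this assay. The expected step is a 1.0-fold higher number from compound 3 to compound 4 (0.02 log units; within the scatter). For compound 4 the estimated value is 70000 nM, with an expected range of 30000 nM to 170000 nM.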

Compound 4, half-maximal inhibitory concentration: 13300 nM
The estimate for compound 4 lay 5.3-fold (0.72 log units) above the measured number; measured number below the stated range.
By their numbers in this assay, from the lowest: compound 4; then compounds 2 and 3 (each within the scatter of the next); then compound 1.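

In this assay, among these compounds, this position can carry a wider change than the earlier steps showed, with a 13-fold lower number from compound 1 to compound 4 (1.11 log units; beyond the scatter) being large where every earlier step was modest or smaller. The 3-chloro-4-fluorophenyl group also stands apart from the other halogen-bearing groups, with a 5.0-fold lower number from compound 3 to compound 4 (0.70 log units; beyond the scatter) and a 4.5-fold lower number from compound 2 to compound 4 (0.66 log units; beyond the scatter) both beyond the scatter, so a halogen on the phenyl ring does not alone give the lowest number here. No measurement at hand accounts for this difference.

Going by these compounds, it remains open whether the chlorine, the fluorine or the pair matters in 3-chloro-4-fluorophenyl. Also open, on these data alone, is what a phenyl ring bearing a methoxy group or an amine would give on this nitrogen.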